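The source may hold more compounds than are shown below. What is called first, only, known or untested is meant among the compounds shown, and "the series" means these compounds.

Compound 1, `CN1CCC[C@H]1[C@@H]1COc2cc(N)ccc2O1`: 3500 nM
Compound 2, `CN1CCC[C@H]1[C@@H]1COc2cc([N+](=O)[O-])ccc2O1`: 15000 nM
Compound 3, `CN1CCC[C@H]1[C@H]1COc2cc([N+](=O)[O-])ccc2O1`: 4800 nM

All three were measured in an assay on membranes from HEK293 cells for displacement of a labelled ligand from Neuronal acetylcholine receptor; alpha3/beta4 (Homo sapiens), with a stated time of 5 min; on this read-out higher numbers stand for weaker inhibition and lower numbers for stronger inhibition. Among them compound 2 gives the highest number. Its nearest neighbour is compound 3, as the step of a 3.1-fold lower number from compound 2 to compound 3 (0.49 log units; beyond the scatter) shows, and the step of a 4.3-fold higher number from compound 1 to compound 2 (0.63 log units; beyond the scatter) places compound 1 furthest away. The difference between compound 2 and compound 3 rests on (the fact that compounds 2 and 3 differ only in the configuration as drawn), so that step speaks only to configuration.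

The next compound, compound 4, `CN1CCC[C@H]1[C@@H]1COc2cc(O)ccc2O1`, has not yet been measured in this assay. Compared with compound 2 it shows (hydroxy in place of nitro on an aromatic carbon). Of the measured steps, only a 4.3-fold higher number from compound 1 to compound 2 (0.63 log units; beyond the scatter) bears on this change: there an amino group on the same aromatic carbon, with the same configuration as in compound 2 and compound 4, gave a modestly lower number than the nitro group. Among the compounds with values here, a hydroxy group, like an amino group, carries a hydrogen-bond donor, and the single step seen with the amino group is the only guide available. On that basis a modest move back toward the number of compound 1 is expected for compound 4, which would mean a 3.3-fold lower number from compound 2 to compound 4 (0.52 log units; beyond the scatter). For compound 4 the estimate in this assay is therefore 4500 nM, with a range from 1500 nM to 13000 nM.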

Compound 4, inhibition constant: 1900 nM
The estimate for compound 4 lay 2.4-fold (0.37 log units) above the measured number; low and high end bracket the measured number.
By their numbers in this assay, from the lowest: compounds 4, 1 and 3 (each within the scatter of the next, the first and the last beyond it); then compound 2.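

In this assay, the nitro group on this aromatic carbon now has two replacements, and both give a lower number beyond the scatter: hydroxy (a 7.9-fold lower number from compound 2 to compound 4 (0.90 log units; beyond the scatter)) joins the amino group seen earlier (a 4.3-fold higher number from compound 1 to compound 2 (0.63 log units; beyond the scatter)). The result also shows that the two replacements cannot be separated at this position, since the hydroxy and amino compounds lie within the scatter of each other (a 1.8-fold lower number from compound 1 to compound 4 (0.27 log units; within the scatter)), so in this small set it is the nitro compound that stands apart among the three compounds sharing this configuration. What is known about these compounds gives no explanation for the step from nitro to hydroxy, as the only available observation concerns configuration and not this change.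

On these data alone, it remains open whether the hydrogen-bond donor that hydroxy brings in has anything to do with the lower number, a question that a methoxy group or a fluorine atom on the same carbon would help to settle. As far as these compounds go, it is also open whether the change of configuration seen with the nitro group in compound 2 and compound 3 would carry over to the hydroxy group of compound 4.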